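Notes on the step from compound 3 to compound 4

A few compounds are considered here, and "the series" means these few. Any claim that something is new, unique, unknown or untested is made for them only; others in the source may bear on it.

Compound 1 `O=c1cc(/C=N\O)c2c(OCc3ccccc3)cc(OCc3ccccc3)cc2o1`: > 2000000 nM
Compound 2 `N/N=C\c1cc(=O)oc2cc(OCc3ccccc3)cc(OCc3ccccc3)c12`: 36500 nM
Compound 3 `O=c1cc(/C=N\Nc2ccc([N+](=O)[O-])cc2)c2ccc(OCc3ccccc3)cc2o1`: > 2000000 nM

In a functional assay, read by spectrophotometry, with a stated time of 5 min (a lower number here means a stronger inhibitor, a higher number a weaker inhibitor), compound 1 reaches only the limit of the assay, > 2000000 nM. Among the compounds with values here, compound 2 gives 36500 nM in this assay; the step of an at least 54-fold lower number from compound 1 to compound 2 (1.73 log units; beyond the scatter) is the only measured step in the set. Compound 3 also sits at the limit, > 2000000 nM, as two of the three values do (the limit of > 2000000 nM in this assay, at which 2 of the 3 values shown sit). Compound 4 `O=c1cc(/C=N\Nc2ccc([N+](=O)[O-])cc2)c2c(OCc3ccccc3)cc(OCc3ccccc3)cc2o1` differs from compound 3 by benzyloxy in place of hydrogen on an aromatic carbon. Within the data shown here, no measured step involves a benzyloxy addition; the step from compound 1 to compound 2 changes a different group and does not bear on this one. Compound 1, which carries the benzyloxy group too, sits at the limit. Compound 4 is therefore expected to remain near the limit, a number no higher from compound 3 to compound 4 (the limit leaves the size open), with an estimated 2000000 nM and a range from 300000 nM to 8000000 nM.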

Compound 4, half-maximal inhibitory concentration: 419000 nM
Estimate against measurement, compound 4: 4.8-fold (0.68 log units) above; the measured number falls inside the stated range.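

In this assay, benzyloxy in place of hydrogen on an aromatic carbon, ortho to a fused ring, brings a real gain: an at least 4.7-fold lower number from compound 3 to compound 4 (0.67 log units; beyond the scatter). The 4-nitrophenyl group on the amine nitrogen loses ground against the free amine, an 11-fold higher number from compound 2 to compound 4 (1.06 log units; beyond the scatter), yet (4-nitrophenyl)amino still improves on hydroxy, an at least 4.7-fold lower number from compound 1 to compound 4 (0.67 log units; beyond the scatter). Two of these steps have only a lower bound on their size: the limit of > 2000000 nM in this assay, at which 2 of the 4 values shown sit.

On these data alone, whether the benzyloxy gain also holds with amino or hydroxy on the double-bonded nitrogen stays open. As far as these compounds go, how methoxy or a carboxylic acid on that aromatic carbon would compare also stays open.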